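This account rests on a few compounds, and the source may have more. Where it says the series, first, only, none or still open, it means among the compounds named here.

For the measured compounds named here, compound 2 `CC(C)(C)c1ccc(C(=O)N2CCC3(CC2)C(=O)N(CC(=O)N2CCC(O)CC2)CN3c2ccccc2)cc1` gives 4700 nM in an assay on HEK293 cells for displacement of a labelled ligand from NPC1-like intracellular cholesterol transporter 1 (Homo sapiens) (a lower number here means a stronger inhibitor, a higher number a weaker inhibitor), the higher of the two numbers known; compound 3 `CCc1nn(CC)c(C2CCN(C(=O)CN3CN(c4ccccc4)C4(CCN(C(=O)c5ccc(C(C)(C)C)cc5)CC4)C3=O)CC2)c1C` gives 2500 nM, and a 1.9-fold lower number from compound 2 to compound 3 (0.27 log units; within the scatter). For compound 1 `CC(C)(C)OC(=O)NCCCCNC(=O)CN1CN(c2ccccc2)C2(CCN(C(=O)c3ccc(C(C)(C)C)cc3)CC2)C1=O` the outcome in this assay is recorded as "not determined" (no result reported). Compound 4 `CC(C)(C)OC(=O)NCCCNC(=O)CN1CN(c2ccccc2)C2(CCN(C(=O)c3ccc(C(C)(C)C)cc3)CC2)C1=O` differs from compound 2 as follows: (3-((tert-butoxycarbonyl)amino)propyl)amino in place of 4-hydroxypiperidin-1-yl on a carbonyl carbon. Going by the values given here, the single measured step, which exchanged only the hydroxy on a saturated ring carbon, is the only guide, and it stayed within the scatter, so no step beyond the scatter is expected in this assay for the present change either. Compound 4 is therefore estimated at 4000 nM, within 1300 nM to 12000 nM, meaning an expected 1.2-fold lower number from compound 2 to compound 4 (0.07 log units; within the scatter).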

Compound 4, half-maximal inhibitory concentration: 4500 nM
Compound 4: the middle estimate sits 1.1-fold (0.05 log units) below what was measured; the measured number falls inside the stated range.
By their numbers in this assay, from the lowest: compounds 3, 4 and 2 (each within the scatter of the next).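

In this assay, exchanging the 4-hydroxypiperidin-1-yl on the carbonyl carbon for (3-((tert-butoxycarbonyl)amino)propyl)amino gives a 1.0-fold lower number from compound 2 to compound 4 (0.02 log units; within the scatter), so the step stays within the scatter. The earlier step changed only the hydroxy and kept the saturated ring, whereas this one removes that ring and puts an open chain in its place, also without leaving the scatter. No supporting evidence bears on this result. The compounds shown leave open whether a free primary amine or a carboxylic acid at the end of this chain, or a longer chain, would give a step beyond the scatter.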